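Replacing an Amide by a Urea on a Shared Core

The compounds below may be only part of what the source reports. "The series", "measured", "known", "first", "only" and "open" are said of these compounds alone.

Measured so far:
compound 1, `COc1cc(-c2nn(-c3cccc(NC(=O)c4ccc(Cl)c(C(F)(F)F)c4)c3)cc2-c2ccncc2)ccc1Cl`: > 32500 nM
compound 2, `O=C(Nc1cccc(-n2cc(-c3ccncc3)c(-c3ccc(Cl)c(O)c3)n2)c1)Nc1cc(C(F)(F)F)cc(C(F)(F)F)c1`: 5110 nM

Both compounds were tested in a functional assay on SW-620 cells (Homo sapiens) for inhibition, read by sulforhodamine B assay, with a stated time of 48 h; on this read-out higher numbers stand for weaker inhibition of growth and lower numbers for stronger inhibition of growth. For compound 1 the result is not a number but a limit of the assay: compound 1 gives > 32500 nM, which is the limit of > 32500 nM in this assay, at which 1 of the 2 values shown sits. Compound 2, a urea rather than an amide and with a hydroxy group on its core, gives 5110 nM in this assay.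

Compound 3, `COc1cc(-c2nn(-c3cccc(NC(=O)Nc4cccc(C(F)(F)F)c4)c3)cc2-c2ccncc2)ccc1Cl`, has not been measured yet. It keeps the core of compound 1 and changes only the group on the carbonyl carbon: (3-(trifluoromethyl)phenyl)amino in place of 4-chloro-3-(trifluoromethyl)phenyl on a carbonyl carbon. Since compound 1 sits at the limit, any real number for compound 3 would be a step toward stronger growth inhibition; the step from compound 1 to compound 3 is expected to be an at least 2.7-fold lower number from compound 1 to compound 3 (0.43 log units; beyond the scatter). Compound 3 is therefore estimated at 12000 nM in this assay, within a range from 3000 nM to 40000 nM.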

Compound 3, concentration for total growth inhibition: 14300 nM
Estimate against measurement, compound 3: 1.2-fold (0.08 log units) below; measured number inside the range.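

Going by these compounds alone, on the shared core, with the group on the carbonyl carbon as the only change, (3-(trifluoromethyl)phenyl)amino in place of 4-chloro-3-(trifluoromethyl)phenyl gives, in this assay, an at least 2.2-fold lower number from compound 1 to compound 3 (0.35 log units; beyond the scatter). Within the data shown here, this is the first comparison here that isolates this position, and it shows that a change at this one place on the carbonyl carbon is enough to bring a measurable number, which compound 2, differing from compound 1 in more than one place, could not show. The full size of the step stays unknown because the result for compound 1 is a limit and not a number: the limit of > 32500 nM in this assay, at which 1 of the 3 values shown sits.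

The exchange adds an amino nitrogen and removes a chlorine at once, and the compounds shown cannot separate these two parts. Also open, going by these compounds, is how a cyclohexylamino group, which has no aromatic ring, behaves on the same carbonyl carbon.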